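The source may hold more compounds than are shown below. What is called first, only, known or untested is meant among the compounds shown, and "the series" means these compounds.

Measured so far:
compound 1 `Cc1nc2ccccc2c(=O)n1NC(=O)Nc1ccc(Cl)cc1` gives 48% in a functional assay on the whole organism for inhibition, with Mus musculus as the target, with a stated time of 1 h, at a dose of 100 mg/kg by the intraperitoneal route; a lower number here means less inhibition, a higher number more inhibition at the dose given (going by the name of the read-out)
compound 2 `Cc1nc2ccccc2c(=O)n1NC(=O)Nc1ccc([N+](=O)[O-])cc1` gives 40% in this assay

Compound 2 stands lowest of the two numbers; its nearest neighbour is compound 1, and the step of a number 8 percentage points lower from compound 1 to compound 2 (within the scatter) lies within the scatter. Compound 3 `CCOc1ccc(NC(=O)Nn2c(C)nc3ccccc3c2=O)cc1` is not yet measured. It differs from compound 2 by ethoxy in place of nitro on an aromatic carbon. Going by the values given here, the only measured step, a number 8 percentage points lower from compound 1 to compound 2 (within the scatter), touches the same place and did not move the read-out beyond the scatter; no step with ethoxy exists. No step beyond the scatter is therefore expected: a number 4 percentage points higher from compound 2 to compound 3 (within the scatter). For compound 3 the estimate is 44%, with a range of 28% to 60%.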

Compound 3, a percentage reported as inhibition, in the whole organism at one dose (the size of the read-out at that dose, not a potency): 45%
Compound 3: the middle estimate sits 1 percentage points below what was measured, within the range that was stated.
By their numbers in this assay, from the lowest: compounds 2, 3 and 1 (each within the scatter of the next).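

On the aromatic carbon para to a large group, ethoxy now stands alongside nitro and chloro in this assay, with the steps of a number 5 percentage points higher from compound 2 to compound 3 (within the scatter) and a number 3 percentage points lower from compound 1 to compound 3 (within the scatter). An ether group at this place therefore separates from neither of the other two, so these three groups give no order at this dose. Nothing available explains this flat result.

On these data alone, an amine, a carboxylic acid or a longer alkoxy chain at this place remains open. So does whether any group here can move the read-out beyond the scatter.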